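This account rests on a few compounds, and the source may have more. Where it says the series, first, only, none or still open, it means among the compounds named here.

Compound 1 `O=C1/C(=C/c2coc3ccccc3c2=O)N=C(c2ccc(Cl)cc2)N1c1ccc(S(=O)(=O)Nc2ncccn2)cc1` holds the highest of the two numbers in a functional assay on A549 cells (Homo sapiens) for cytotoxicity, read by sulforhodamine B assay, with a stated time of 72 h (on this read-out higher numbers stand for weaker inhibition and lower numbers for stronger inhibition), giving 59000 nM; compound 2 `Cc1cc(C)nc(NS(=O)(=O)c2ccc(N3C(=O)/C(=C/c4coc5ccccc5c4=O)N=C3c3ccc(Cl)cc3)cc2)n1` gives 52600 nM, and the step of a 1.1-fold lower number from compound 1 to compound 2 (0.05 log units; within the scatter) stays within the scatter. Compound 3 `O=C1/C(=C/c2coc3ccccc3c2=O)N=C(c2ccccc2)N1c1ccc(S(=O)(=O)Nc2ncccn2)cc1` differs from compound 1 by hydrogen in place of chloro on an aromatic carbon. Within the data shown here, the one measured step sits on the sulfonamide nitrogen and does not reach the ring carrying the chloro, so no measured step bears directly on this change. The expectation for compound 3 is therefore no step beyond the scatter, no change at the digits printed from compound 1 to compound 3 (within the scatter). Compound 3 is expected at 59000 nM, within a range of 28000 nM to 125000 nM.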

Compound 3, half-maximal inhibitory concentration: 40500 nM
Compound 3: middle estimate off by 1.5-fold (0.16 log units), on the high side; measured number inside the range.
By their numbers in this assay, from the lowest: compounds 3, 2 and 1 (each within the scatter of the next).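

Notes on the series: in this assay, the first reading on the aryl group shows that 4-chlorophenyl to phenyl, on an aromatic carbon para to a large group, stays within the scatter (a 1.5-fold lower number from compound 1 to compound 3 (0.16 log units; within the scatter)). At this place, hydrogen and chloro are therefore not told apart by this read-out, at numbers this high. No measurement in hand offers an explanation for this reading.

Open, from the compounds shown here alone, is whether a group of another kind at this carbon, such as an amine, a methoxy or a carboxylic acid, would move the number beyond the scatter. Also open, going by these compounds, is whether any change on the shared core gives a clearly lower number.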